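The source may hold more compounds than are shown below. What is called first, only, known or untested is meant among the compounds shown, and "the series" means these compounds.

Of the compounds shown here, three sharing one core have been tested in an ADME assay on L6 cells (Rattus norvegicus) for cytotoxicity, read by resazurin assay, with a stated time of 72 h; a higher number here means a weaker inhibitor, a lower number a stronger inhibitor. Compound 1 (`N/C(CC(O)c1cccc2ccccc12)=N\N=C\c1ccc(Cl)c(Cl)c1`) gives 16000 nM, compound 2 (`COc1ccc(/C=N/N=C(\N)CC(O)c2cccc3ccccc23)cc1`) gives 6300 nM and compound 3 (`N/C(CC(O)c1cccc2ccccc12)=N\N=C\c1ccc(F)c(F)c1`) gives 17000 nM. Compound 3 thus sits in the upper pair of this small set: the data show a 1.1-fold higher number from compound 1 to compound 3 (0.03 log units; within the scatter), and also a 2.7-fold higher number from compound 2 to compound 3 (0.43 log units; beyond the scatter). Compound 4 (`N/C(CC(O)c1cccc2ccccc12)=N\N=C\c1ccco1`) has furan-2-yl in place of 3,4-difluorophenyl on a carbon with a double bond to nitrogen. Within the data shown here, no measured compound carries furan-2-yl, so the evidence is indirect. Changes at this same place have been small so far, ranging from a 1.1-fold higher number from compound 1 to compound 3 (0.03 log units; within the scatter) to a 2.5-fold lower number from compound 1 to compound 2 (0.40 log units; beyond the scatter) and a 2.7-fold higher number from compound 2 to compound 3 (0.43 log units; beyond the scatter). In this assay, a step within the scatter is therefore expected, with a modest step in either direction still possible. The expected step is a 1.1-fold lower number from compound 3 to compound 4 (0.05 log units; within the scatter). Compound 4 is estimated at 15000 nM, with an expected range of 6000 nM to 40000 nM.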

Compound 4, half-maximal inhibitory concentration: 145000 nM
The estimate for compound 4 lay 9.7-fold (0.99 log units) below the measured number; measured number above the stated range.
By their numbers in this assay, from the lowest: compound 2; then compounds 1 and 3 (each within the scatter of the next); then compound 4.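

In this assay this position proves able to carry much larger steps than the exchanges among the three phenyl groups suggested: furan-2-yl brings an 8.5-fold higher number from compound 3 to compound 4 (0.93 log units; beyond the scatter) and a 9.1-fold higher number from compound 1 to compound 4 (0.96 log units; beyond the scatter) as well as a 23-fold higher number from compound 2 to compound 4 (1.36 log units; beyond the scatter) at the same place. The number rises whichever phenyl group leaves, as a six-membered aromatic ring of carbon only gives way to a five-membered aromatic ring with 1 hetero atom. Nothing at hand offers an explanation for this rise.

From the compounds shown here alone, whether the rise follows the smaller ring or its oxygen remains open, and a thiophen-2-yl group, with sulfur in the five-membered ring, would help to separate the two. Also open, going by these compounds, is how an unsubstituted phenyl or a pyridine ring would compare at this place.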